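The source may report more compounds than this note shows. Statements on the series, on what has been measured and on what is new or still open speak of the compounds shown alone.

In a functional assay on brain (Rattus norvegicus, strain Wistar) for inhibition (a higher number here means a weaker inhibitor, a lower number a stronger inhibitor), compound 1 `Cc1[nH]c(=O)n(C2CCCCC2)c1-c1ccccc1` gives 47600 nM and compound 2 `COc1ccc(-c2c(C)[nH]c(=O)n2C)cc1` gives 147000 nM. Compound 2 therefore has the higher of the two numbers and is the weaker inhibitor of the pair, with a gap beyond the usual scatter. Compound 3 `Cc1[nH]c(=O)n(C)c1-c1ccc(OCCC(C)C)cc1` differs from compound 2 at one place: isobutyl in place of hydrogen on a saturated chain carbon bound to an oxygen on an aromatic ring. This puts isobutyl in place of hydrogen on a saturated chain carbon bound to an oxygen on an aromatic ring, turning methoxy into isopentyloxy.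

Among the measured compounds shown here, no measured pair shows this change on its own, so the expectation is loose. The only guide is that compound 1, at 47600 nM, shows that a lower number than that of compound 2 is reachable among these compounds. A moderate step of a 2.9-fold lower number from compound 2 to compound 3 (0.47 log units; beyond the scatter) is expected, towards a lower number in this assay, though a step within the scatter would not be surprising. For compound 3 the estimated value is 50000 nM, with an expected range from 15000 nM to 150000 nM.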

Compound 3, half-maximal inhibitory concentration: 6600 nM
Compound 3: the middle estimate sits 7.6-fold (0.88 log units) above what was measured, and the stated range ends above it.
By their numbers in this assay, from the lowest: compound 3; then compound 1; then compound 2.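

In this assay, among the compounds shown here, the change from methoxy to isopentyloxy gives the first direct reading at this place, a saturated chain carbon bound to an oxygen on an aromatic ring: isobutyl in place of hydrogen produces a 22-fold lower number from compound 2 to compound 3 (1.35 log units; beyond the scatter) and so a large step beyond the scatter. The position therefore tolerates an addition of 4 heavy atoms, all carbon, with no ring, no hydrogen-bond donors or acceptors and no net charge, and the number falls rather than rises. No supporting measurement bears on this step, so the reason for the fall remains unknown.

As far as these compounds go, a single step cannot separate the contribution of chain length from that of the branch, so it remains open how an unbranched pentyl chain, a shorter ethyl group or a longer chain would compare with isopentyl at this place. From the compounds shown here alone, it is also open whether the lower number would persist with an amine, a carboxylic acid or a phenyl ring at the end of the chain, or whether this change would have a similar effect on a core carrying a cyclohexyl group.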